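The compounds below may be only part of what the source reports. "The series", "measured", "known", "first", "only" and "open" are said of these compounds alone.

Compound 3 `CCc1cc(Cn2c(CC)nc3c(C)cc(C)nc32)ccc1OC(C(=O)O)c1ccccc1` gives the lowest number of the three in an assay on Midbrain with Type-2 angiotensin II receptor (Rattus norvegicus) as the target (on this read-out lower numbers stand for stronger inhibition and higher numbers for weaker inhibition), at 410 nM. Compound 1 `CCc1nc2c(C)cc(C)nc2n1Cc1ccc(OC(C(=O)O)c2ccccc2)c(Cl)c1` gives 720 nM in this assay and compound 2 `CCc1nc2c(C)cc(C)nc2n1Cc1ccc(OC(C(=O)O)c2ccccc2)c(C)c1` gives 940 nM; the step of a 1.8-fold lower number from compound 1 to compound 3 (0.24 log units; within the scatter) lies within the scatter, whereas a 2.3-fold lower number from compound 2 to compound 3 (0.36 log units; beyond the scatter) is beyond it. Compound 4 `CCCCc1cc(Cn2c(CC)nc3c(C)cc(C)nc32)ccc1OC(C(=O)O)c1ccccc1` carries ethyl in place of hydrogen on a saturated chain carbon, two bonds along the chain from an aromatic carbon, so the chain on the aromatic carbon grows from ethyl to butyl. Among the compounds with values here, the only step bearing on chain length here is a 2.3-fold lower number from compound 2 to compound 3 (0.36 log units; beyond the scatter), a modest gain on adding one carbon; a 1.3-fold higher number from compound 1 to compound 2 (0.12 log units; within the scatter) says nothing about further extension. A further step in the same direction, at most of similar size and quite possibly within the scatter, is therefore expected: a 1.4-fold lower number from compound 3 to compound 4 (0.14 log units; within the scatter). Compound 4 is estimated at 300 nM, with a range from 120 nM to 750 nM.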

Compound 4, half-maximal inhibitory concentration: 140 nM
Compound 4: the middle estimate sits 2.1-fold (0.33 log units) above what was measured; the range from low to high includes it.
By their numbers in this assay, from the lowest: compound 4; then compounds 3, 1 and 2 (each within the scatter of the next, the first and the last beyond it).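

In this assay, growing the ethyl of compound 3 to butyl gives a 2.9-fold lower number from compound 3 to compound 4 (0.47 log units; beyond the scatter), so lengthening this chain beyond ethyl still lowers the number by more than the scatter. Set against the methyl and chloro groups on the same aromatic carbon, the butyl chain gives a 6.7-fold lower number from compound 2 to compound 4 (0.83 log units; beyond the scatter) and a 5.1-fold lower number from compound 1 to compound 4 (0.71 log units; beyond the scatter), both also beyond the scatter. Nothing available explains this result.

On these data alone, whether a propyl chain falls on the same trend, and whether a longer chain such as hexyl lowers the number further, remains open. As far as these compounds go, a branched chain such as isobutyl, or a chain ending in a hydroxyl, is also open.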